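Stereochemistry in a benzyl-protected pyranose series on HL-60 cells

This account rests on a few compounds, and the source may have more. Where it says the series, first, only, none or still open, it means among the compounds named here.

Measured compounds:
compound 1 `CC(C)C[C@H]1O[C@H](COCc2ccccc2)[C@H](OCc2ccccc2)[C@H](OCc2ccccc2)[C@H]1O`: "not active" (no number reported)
compound 2 `CC(C)C[C@H]1O[C@H](COCc2ccccc2)[C@@H](OCc2ccccc2)[C@H](OCc2ccccc2)[C@H]1O`: 13900 nM

Within the data shown here, in a functional assay on HL-60 cells (Homo sapiens) for antiproliferative activity, read by MTT assay (on this read-out higher numbers stand for weaker inhibition and lower numbers for stronger inhibition), compound 2 gives 13900 nM, the only number in the set. Compound 1 is recorded as "not active" (no number reported), reported without a number, although (the fact that compounds 1 and 2 differ only in the configuration as drawn). Compound 3 `CC(C)C[C@@H]1O[C@H](COCc2ccccc2)[C@H](OCc2ccccc2)[C@H](OCc2ccccc2)[C@H]1O` has not been tested; against compound 2 the change is the two compounds have the same atoms and bonds and differ only in configuration as drawn: 2 of 5 stereo elements differ; a stereocentre at a saturated ring carbon is drawn R in compound 2 and S in compound 3; a stereocentre at a saturated ring carbon is drawn R in compound 2 and S in compound 3. Among the measured compounds shown here, no measured step between two compounds is available to size this change. A step from compound 2 to compound 3 of a 2.2-fold higher number from compound 2 to compound 3 (0.33 log units; beyond the scatter) toward weaker inhibition is expected, with a real chance of no number at all. Compound 3 is estimated at 30000 nM, between 8000 nM and 100000 nM.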

Compound 3, half-maximal inhibitory concentration: "not active" (no number reported)
Compound 3 has no reported number here; no gap can be computed for the estimate.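

Among these compounds, compound 3, like compound 1, carries no number, so no step from compound 2 to either can be read. The compounds shown leave open how much each of the differing stereocentres contributes on its own.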